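Trifluoromethyl in Place of Nitro on the Amide-Side Ring

The source may report more compounds than this note shows. Statements on the series, on what has been measured and on what is new or still open speak of the compounds shown alone.

Three compounds sharing one core were tested in a functional assay on MGC-803 cells (Homo sapiens) for inhibition, read by MTT assay, with a stated time of 72 h; on this read-out higher numbers stand for weaker inhibition and lower numbers for stronger inhibition. Compound 1 `O=C(CSc1nc(Nc2ccccc2)c2ccccc2n1)Nc1ccccc1Cl` gives 24800 nM. Compound 2 `O=C(CSc1nc(Nc2ccccc2)c2ccccc2n1)Nc1cccc(Br)c1` gives 9620 nM, a change of a 2.6-fold lower number from compound 1 to compound 2 (0.41 log units; beyond the scatter). Compound 3 `O=C(CSc1nc(Nc2ccccc2)c2ccccc2n1)Nc1ccc([N+](=O)[O-])cc1` reaches only a limit of the assay, > 50000 nM, and so no number is known for it; the limit of > 50000 nM in this assay, at which 1 of the 3 values shown sits, marks where it sits. The steps into compound 3 read an at least 2.0-fold higher number from compound 1 to compound 3 (0.30 log units; that floor lies within the scatter) and an at least 5.1-fold higher number from compound 2 to compound 3 (0.71 log units; beyond the scatter), so compound 3 stands at the weak end of what is shown.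

Compound 4 `O=C(CSc1nc(Nc2ccccc2)c2ccccc2n1)Nc1ccc(C(F)(F)F)cc1` is not yet measured. It differs from compound 3 by trifluoromethyl in place of nitro on an aromatic carbon. Going by the values given here, no measured step replaces nitro with trifluoromethyl, so only the two steps into compound 3 bear on it, and both moved toward higher numbers. Compound 4 is therefore expected to give a number near the limit, with an estimated step of an at least 1.6-fold lower number from compound 3 to compound 4 (0.22 log units; that floor lies within the scatter) toward a lower number. For compound 4 the estimate in this assay is 30000 nM, between 8000 nM and 100000 nM.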

Compound 4, half-maximal inhibitory concentration: 8670 nM
For compound 4 the middle estimate is 3.5-fold (0.54 log units) above the measured one; the measured number falls inside the stated range.
By their numbers in this assay, from the lowest: compounds 4 and 2 (each within the scatter of the next); then compound 1. At a limit, above all of these: compound 3.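

Replacing nitro with trifluoromethyl at this place on the amide-side ring has a clear effect, an at least 5.7-fold lower number from compound 3 to compound 4 (0.76 log units; beyond the scatter), so a group para to a large group on this ring does not by itself put a compound at the weak end in this assay. From the compounds shown here alone, compound 3 remains at a limit of the assay, so the full size of that step is unknown: the limit of > 50000 nM in this assay, at which 1 of the 4 values shown sits. The other steps read a 1.1-fold lower number from compound 2 to compound 4 (0.05 log units; within the scatter), which gives no order between those two, and a 2.9-fold lower number from compound 1 to compound 4 (0.46 log units; beyond the scatter), so the 4-(trifluoromethyl)phenyl ring matches the 3-bromophenyl ring and improves on the 2-chlorophenyl ring.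

The compounds shown leave open how an amine, a carboxylic acid or a methoxy group would read at this place. They also leave open how trifluoromethyl would read elsewhere on this ring.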